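Extending the aryl arm of a TRPV1 antagonist into a phenethyl chain

The compounds below may be only part of what the source reports. "The series", "measured", "known", "first", "only" and "open" are said of these compounds alone.

Three compounds share one core and differ only in the aromatic group attached to the pyridine-type ring. Compound 1 `CC(C(=O)NCc1ccc(C(F)(F)F)nc1-c1ccc(Cl)cc1)c1ccc(NS(C)(=O)=O)c(F)c1` gives 0.7 nM in an assay on CHO cells for antagonist activity at transient receptor potential cation channel subfamily V member 1 (Homo sapiens), read by FLIPR; on this read-out higher numbers stand for weaker inhibition and lower numbers for stronger inhibition. Compound 2 `CC(C(=O)NCc1ccc(C(F)(F)F)nc1-c1ccc(F)c(Cl)c1)c1ccc(NS(C)(=O)=O)c(F)c1` gives 0.2 nM, and compound 3 `CC(C(=O)NCc1ccc(C(F)(F)F)nc1-c1ccc(Cl)c(Cl)c1)c1ccc(NS(C)(=O)=O)c(F)c1` gives 0.9 nM. Compound 3 thus has the highest number of the three; its gap to compound 1 is within the scatter, while the step of a 4.5-fold higher number from compound 2 to compound 3 (0.65 log units; beyond the scatter) is beyond it.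

Compound 4 `Cc1ccc(CCc2nc(C(F)(F)F)ccc2CNC(=O)C(C)c2ccc(NS(C)(=O)=O)c(F)c2)cc1` has not been measured. Relative to compound 3 the change is 2-(4-methylphenyl)ethyl in place of 3,4-dichlorophenyl on an aromatic carbon. Within the data shown here, none of the measured steps covers such a change: a 3.5-fold lower number from compound 1 to compound 2 (0.54 log units; beyond the scatter), a 1.3-fold higher number from compound 1 to compound 3 (0.11 log units; within the scatter) and a 4.5-fold higher number from compound 2 to compound 3 (0.65 log units; beyond the scatter) all swap halogens on a directly attached phenyl ring, whereas here the whole 3,4-dichlorophenyl group leaves and a 2-(4-methylphenyl)ethyl group enters. Among the measured compounds shown here, with no close precedent, the expected step of an 8.9-fold higher number from compound 3 to compound 4 (0.95 log units; beyond the scatter) is uncertain and is taken as a modest loss. Compound 4 is estimated at 8 nM, with a range of 1 nM to 80 nM.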

Compound 4, inhibition constant: 0.6 nM
Beside the measured number, compound 4's estimate is 13-fold (1.12 log units) above it; measured number below the stated range.
By their numbers in this assay, from the lowest: compound 2; then compounds 4, 1 and 3 (each within the scatter of the next).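

This position on the shared core is not limited to a directly attached halogenated phenyl ring: the halogen-free 2-(4-methylphenyl)ethyl group, in which an ethyl chain carries the ring, matches the two chlorinated groups in this assay within the scatter, with a 1.5-fold lower number from compound 3 to compound 4 (0.18 log units; within the scatter) and a 1.2-fold lower number from compound 1 to compound 4 (0.07 log units; within the scatter) as the steps. The 3-chloro-4-fluorophenyl group alone keeps a clear edge over it, shown by a 3.0-fold higher number from compound 2 to compound 4 (0.48 log units; beyond the scatter) beyond the scatter. Nothing measured here accounts for this tolerance of a longer arm.

On these data alone, whether a longer chain such as 3-phenylpropyl would hold the number at this position stays open, as does the effect of an amine or a carboxylic acid in place of the ring's methyl. The compounds shown also leave open what the methyl itself contributes, as they include no unsubstituted phenethyl partner.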